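The compounds below may be only part of what the source reports. "The series", "measured", "known", "first", "only" and "open" are said of these compounds alone.

Measured so far:
compound 1 `CN(c1ccn(C)n1)c1cnc(NCc2c(F)ccc3c2CCO3)c2cn[nH]c(=O)c12`: 12000 nM
compound 2 `CN(C)Cc1ccc2c(c1)CN(c1cnc(NCc3c(F)ccc4c3CCO4)c3cn[nH]c(=O)c13)C2=O`: 174000 nM
compound 3 `CN(c1ncco1)c1cnc(NCc2c(F)ccc3c2CCO3)n2cnnc12`: 67000 nM

All three were tested in a physicochemical assay for solubility, read by LC-MS, in phosphate buffer, with a stated time of 24 h, at pH 7.4; a higher number here means a more soluble compound, a lower number a less soluble compound. Compound 1 gives the lowest of the three solubility numbers; compound 3 lies above it by more than the usual scatter, and compound 2 lies furthest above. Compound 4 `Cc1nc(CO)ccc1-c1cnc(NCc2c(F)ccc3c2CCO3)c2cn[nH]c(=O)c12` has not yet been measured. It differs from compound 1 in one place: 6-(hydroxymethyl)-2-methylpyridin-3-yl in place of methyl(1-methyl-1H-pyrazol-3-yl)amino on an aromatic carbon. For the measured compounds named here, no measured pair shows an exchange of this kind, so the direction has to be judged from the change itself. A moderate rise, near the edge of the scatter, is expected: a 1.8-fold higher number from compound 1 to compound 4 (0.26 log units; within the scatter). Compound 4 is therefore estimated at 22000 nM, within a range from 6000 nM to 75000 nM.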

Compound 4, solubility: 3000 nM
Compound 4: middle estimate off by 7.3-fold (0.87 log units), on the high side; the whole stated range lies above it.
By their numbers in this assay, from the lowest: compound 4; then compound 1; then compound 3; then compound 2.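

In this assay the position is sensitive to what it carries: 6-(hydroxymethyl)-2-methylpyridin-3-yl in place of methyl(1-methyl-1H-pyrazol-3-yl)amino gives a 4.0-fold lower number from compound 1 to compound 4 (0.60 log units; beyond the scatter) on this aromatic carbon. The entering group brings 1 hydrogen-bond donor where the leaving group has 0, yet the number falls in this pair. Nothing measured here explains the fall.

As far as these compounds go, the pyridine ring, its methyl and its hydroxymethyl all enter together, so their separate shares stay unknown. From the compounds shown here alone, how a carboxylic acid or a simple amine on this carbon would read remains open.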